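A few compounds are considered here, and "the series" means these few. Any claim that something is new, unique, unknown or untested is made for them only; others in the source may bear on it.

In an in vitro ADME assay on microsomes from liver (Rattus norvegicus) for metabolic stability (on this read-out higher numbers stand for fast clearance and lower numbers for slow clearance), compound 3 `Nc1nc(C(F)(F)F)cc2c1[nH]c(=O)n2Cc1ccc(C(F)(F)F)nc1` gives < 8.5 mL.min-1.g-1, which is a limit of the assay and not a number. Compound 1 `Cc1ccc(Cn2c(=O)[nH]c3c(N)nc(C(F)(F)F)cc32)cn1` gives < 8.5 mL.min-1.g-1, also a limit. Compound 3 therefore stands at the limit of < 8.5 mL.min-1.g-1 in this assay, at which 2 of the 3 values shown sit. Compound 2 `Cc1cccc(Cn2c(=O)[nH]c3c(N)nc(C(F)(F)F)cc32)n1` gives a true number, 27 mL.min-1.g-1.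

Compound 4 `CN1CCN(c2ccc(Cn3c(=O)[nH]c4c(N)nc(C(F)(F)F)cc43)cn2)CC1` carries one change from compound 3: 4-methylpiperazin-1-yl in place of trifluoromethyl on an aromatic carbon. In words, this is 4-methylpiperazin-1-yl in place of trifluoromethyl on an aromatic carbon, next to the ring nitrogen.

Among the measured compounds shown here, two measured steps bear on this change. Putting trifluoromethyl in place of methyl gave a step that the two limits leave unreadable from compound 1 to compound 3, so that swap offers no size to work from. Putting 6-methylpyridin-2-yl in place of 6-methylpyridin-3-yl gave an at least 3.1-fold higher number from compound 1 to compound 2 (0.50 log units; beyond the scatter), which shows in compound 2 that a change in this part of the molecule can move the read-out beyond the scatter. For the measured compounds named here, no measured step involves the entering group itself, so the expectation is loose. A modest rise is expected, estimated as an at least 2.3-fold higher number from compound 3 to compound 4 (0.37 log units; beyond the scatter). The estimate for compound 4 is 20 mL.min-1.g-1, with an expected range from 8 mL.min-1.g-1 to 50 mL.min-1.g-1.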

Compound 4, intrinsic clearance in microsomes: 46 mL.min-1.g-1
Beside the measured number, compound 4's estimate is 2.3-fold (0.36 log units) below it; the measured number falls inside the stated range.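

Until now this position gave no readable size, since swapping methyl for trifluoromethyl left both compounds at a limit. With 4-methylpiperazin-1-yl on this aromatic carbon next to the ring nitrogen, this assay now shows that the group at this place can move clearance beyond the scatter: an at least 5.4-fold higher number from compound 3 to compound 4 (0.73 log units; beyond the scatter), and against the methyl group, an at least 5.4-fold higher number from compound 1 to compound 4 (0.73 log units; beyond the scatter). Both steps give only a smallest possible size, because compound 1 and compound 3 each stand at a limit and not at a number: the limit of < 8.5 mL.min-1.g-1 in this assay, at which 2 of the 4 values shown sit.

The compounds shown leave open which part of the 4-methylpiperazin-1-yl group goes with the rise, and a morpholine, a piperidine or a dimethylamino group at this place would help to separate the ring from its nitrogens. Also open, from the compounds shown here alone, is whether a small group such as methoxy or fluorine would stay at the limit.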